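The compounds below may be only part of what the source reports. "The series", "measured", "known", "first", "only" and "open" are said of these compounds alone.

Compound 1 `c1cc(CN2CCN(CCCc3c[nH]c4ccc(-n5cnnc5)cc34)CC2)ccn1` carries a (pyridin-4-yl)methyl group on an amine nitrogen in a ring. For the measured compounds named here, in an assay on CHO cells for displacement of a labelled ligand from 5-hydroxytryptamine receptor 1D (Homo sapiens) (on this read-out higher numbers stand for weaker inhibition and lower numbers for stronger inhibition), compound 1 gives 0.6 nM, the lowest of the three numbers measured so far. Compound 2 `c1cc2[nH]cc(CCCN3CCNCC3)c2cc1-n1cnnc1` has hydrogen on that nitrogen and gives 31 nM; compound 3 `CN1CCN(CCCc2c[nH]c3ccc(-n4cnnc4)cc23)CC1` has methyl there and gives 33 nM. The step of a 52-fold higher number from compound 1 to compound 2 (1.71 log units; beyond the scatter) and the step of a 55-fold higher number from compound 1 to compound 3 (1.74 log units; beyond the scatter) both show that losing the (pyridin-4-yl)methyl group costs a great deal, while a 1.1-fold higher number from compound 2 to compound 3 (0.03 log units; within the scatter) shows that hydrogen and methyl on that nitrogen cannot be told apart.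

Compound 4 `c1ccc(N2CCN(CCCc3c[nH]c4ccc(-n5cnnc5)cc34)CC2)cc1` has not yet been measured; it differs from compound 1 in one place: phenyl in place of (pyridin-4-yl)methyl on an amine nitrogen in a ring. A six-membered aromatic ring stays on the nitrogen, but the carbon link and the ring nitrogen of the (pyridin-4-yl)methyl group are gone. Going by the values given here, no measured step changes this group in the same way; the two steps from compound 1 only show what full removal does. Because of a 52-fold higher number from compound 1 to compound 2 (1.71 log units; beyond the scatter) and a 55-fold higher number from compound 1 to compound 3 (1.74 log units; beyond the scatter) a weakening beyond the scatter is expected for compound 4, though smaller than full removal, so the expected step is a 13-fold higher number from compound 1 to compound 4 (1.12 log units; beyond the scatter). Compound 4 is therefore estimated to give about 8 nM, with a range from 1.5 nM to 45 nM.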

Compound 4, half-maximal inhibitory concentration: 1.4 nM
Estimate against measurement, compound 4: 5.7-fold (0.76 log units) above; the whole stated range lies above it.
By their numbers in this assay, from the lowest: compound 1; then compound 4; then compounds 2 and 3 (each within the scatter of the next).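

In this assay, the amine nitrogen in a ring turns out to accept a phenyl group directly: replacing the (pyridin-4-yl)methyl group gives only a 2.3-fold higher number from compound 1 to compound 4 (0.37 log units; beyond the scatter), a modest step though beyond the scatter. Phenyl instead of the much smaller groups is a large gain, with a 24-fold lower number from compound 3 to compound 4 (1.37 log units; beyond the scatter) and a 22-fold lower number from compound 2 to compound 4 (1.35 log units; beyond the scatter), so most of the advantage over methyl or hydrogen survives without the carbon link and without the ring nitrogen of the (pyridin-4-yl)methyl group, although these two features left together and their separate shares cannot be told apart. Nothing measured here explains why an aromatic ring on this nitrogen makes such a difference.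

A benzyl group would keep the carbon link without the ring nitrogen, and a pyridin-4-yl group placed directly on the nitrogen would keep the ring nitrogen without the link, so these two could divide the small step between them. A cyclohexyl group would show whether the ring on this nitrogen needs to be aromatic at all.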